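The source may hold more compounds than are shown below. What is called first, only, known or untested is meant among the compounds shown, and "the series" means these compounds.

Measured compounds:
compound 1 `OC(c1ccccc1)c1cccc(OCc2ccc3ccccc3n2)c1` — in an assay on PMNL cells for inhibition of Polyunsaturated fatty acid 5-lipoxygenase (Rattus norvegicus), read by scintillation counting, with a stated time of 3 min (on this read-out lower numbers stand for stronger inhibition and higher numbers for weaker inhibition), compound 1 gives 1800 nM
compound 2 `O=C(O)CSC(CCCc1ccc(Cl)cc1)c1ccc(OCc2ccc3ccccc3n2)cc1` — in this assay compound 2 gives 20 nM

Within the data shown here, compound 2 holds the lower of the two numbers so far; compound 1 sits at a markedly higher number, and that gap lies beyond the scatter. Compound 3 `O=C(O)CSC(CCCc1ccccc1)c1ccc(OCc2ccc3ccccc3n2)cc1` has not yet been measured. It differs from compound 2 in a single place: hydrogen in place of chloro on an aromatic carbon. Among the measured compounds shown here, no step between two measured compounds matches this change, so the expectation rests on the position of compound 2 alone. A change of this kind, one chlorine leaving and a hydrogen entering on an aromatic carbon, is expected to give only a modest step in this assay, most likely toward a higher number, and not far beyond the scatter if at all. For compound 3 the expected result in this assay is 40 nM, with a plausible range from 12 nM to 130 nM. The step this estimate means is a 2.0-fold higher number from compound 2 to compound 3 (0.30 log units; within the scatter), and it is expected to be small.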

Compound 3, half-maximal inhibitory concentration: 70 nM
Compound 3: the middle estimate sits 1.8-fold (0.24 log units) below what was measured; low and high end bracket the measured number.
By their numbers in this assay, from the lowest: compound 2; then compound 3; then compound 1.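

In this assay, among these compounds, going from 4-chlorophenyl to phenyl gives a 3.5-fold higher number from compound 2 to compound 3 (0.54 log units; beyond the scatter) as the first comparison that differs in one place, and it shows that the read-out responds to the group at this aromatic carbon. The step is modest: compound 3 still gives 70 nM without the chloro, so the chlorine contributes to the stronger inhibition of compound 2 but is not needed for inhibition to remain measurable in this read-out. Nothing at hand accounts for the size of this step.

The compounds shown leave open whether the chloro is the best group at this place, since one chloro and one hydrogen say nothing about fluoro, methoxy or trifluoromethyl there, or about chloro on another carbon of the same ring. Also open, from the compounds shown here alone, is whether the step keeps its size and direction when other parts of the structure change, for instance with a primary amide in place of the carboxylic acid or with a shorter chain bearing the phenyl.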